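Swapping a para nitro for methyl on the urea aryl

The source may hold more compounds than are shown below. What is called first, only, known or untested is meant among the compounds shown, and "the series" means these compounds.

Two ureas built on a shared core have been measured in a functional assay on A549 cells (Homo sapiens) for antiproliferative activity, read by MTT assay, with a stated time of 48 h; on this read-out lower numbers stand for stronger inhibition and higher numbers for weaker inhibition. Compound 1 `O=C(Nc1ccc(Cl)cc1)Nc1cccc(NC(=O)c2ccccn2)c1` gives 3620 nM in this assay. Compound 2 `O=C(Nc1ccc([N+](=O)[O-])cc1)Nc1cccc(NC(=O)c2ccccn2)c1` gives 320 nM in this assay, the lowest of the two numbers shown, with compound 1 as its nearest neighbour. For the measured compounds named here, the single measured step, an 11-fold lower number from compound 1 to compound 2 (1.05 log units; beyond the scatter), is the only comparison available.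

Compound 3 `Cc1ccc(NC(=O)Nc2cccc(NC(=O)c3ccccn3)c2)cc1` has not yet been measured in this assay. It differs from compound 2 by methyl in place of nitro on an aromatic carbon. The step from compound 1 to compound 2 bears on this change, since it also involves the nitro group at the same position and was large. Removing the nitro group is therefore expected to move the number upward, and a methyl group, like chloro, is a substituent other than nitro at that position; compound 3 is expected to sit near compound 1 rather than near compound 2, a step of a 13-fold higher number from compound 2 to compound 3 (1.10 log units; beyond the scatter). For compound 3 the estimate in this assay is 4000 nM, within a range of 1200 nM to 15000 nM.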

Compound 3, half-maximal inhibitory concentration: 20 nM
Compound 3: the middle estimate sits 200-fold (2.30 log units) above what was measured, outside the stated range (below it).
By their numbers in this assay, from the lowest: compound 3; then compound 2; then compound 1.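

In this assay, the earlier pair alone could be read as showing that the nitro group carried the low number at this position, but methyl in place of nitro gives a 16-fold lower number from compound 2 to compound 3 (1.20 log units; beyond the scatter) and so removes that reading. Methyl in place of chloro gives a 180-fold lower number from compound 1 to compound 3 (2.26 log units; beyond the scatter) at the same place, which shows that the nitro group is not needed for the lowest number among these three compounds and that the read-out changes strongly with the group on this aromatic carbon. The order from the lowest number, methyl, then nitro, then chloro, comes with no measured property that would account for it.

The compounds shown leave open whether the low number belongs to methyl in particular or extends to other groups at this position, such as an ethyl group, a longer chain, a methoxy group or an amine. They also leave open whether the same order of methyl, nitro and chloro would hold on other cell lines or with the substituent placed elsewhere on the ring.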